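This account rests on a few compounds, and the source may have more. Where it says the series, first, only, none or still open, it means among the compounds named here.

Working notes on the series.

Compound 1 `Brc1cc(N2CC[C@H]3CN[C@H]3C2)cnc1Br` has in a functional assay on HEK293 cells for agonist activity at Neuronal acetylcholine receptor; alpha3/beta4 (Homo sapiens), read by FLIPR (a lower number here means that less compound is needed, a higher number that more compound is needed for the effect), the lower of the two numbers measured: compound 1 gives 8.2 nM there. Among the measured compounds shown here, its mirror image, compound 2 `Brc1cc(N2CC[C@@H]3CN[C@@H]3C2)cnc1Br`, gives 110 nM in this assay, and the step of a 13-fold higher number from compound 1 to compound 2 (1.13 log units; beyond the scatter) is the only measured step in the set. It rests on (the fact that compounds 1 and 2 differ only in the configuration as drawn), so it speaks only to configuration and says nothing about substituents on the aromatic ring.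

Compound 3 `N#Cc1cc(N2CC[C@H]3CN[C@H]3C2)cnc1Br` keeps the configuration of compound 1 and changes one group: cyano in place of bromo on an aromatic carbon. For the measured compounds named here, no measured step bears on this exchange, so no direction can be taken from the data; a step within the scatter, or at most a modest one either way, is the working expectation.

For compound 3 the value in this assay is estimated at 10 nM, with a range of 3 nM to 40 nM. The expected step is therefore a 1.2-fold higher number from compound 1 to compound 3 (0.09 log units; within the scatter).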

Compound 3, half-maximal effective concentration: 4.4 nM
For compound 3 the middle estimate is 2.3-fold (0.36 log units) above the measured one, and the stated range covers the measured number.
By their numbers in this assay, from the lowest: compounds 3 and 1 (each within the scatter of the next); then compound 2.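

In this assay, cyano in place of bromo on this aromatic carbon, ortho to a bromo group and two atoms from the ring nitrogen, gives a 1.9-fold lower number from compound 1 to compound 3 (0.27 log units; within the scatter), so the two compounds cannot be told apart there. Among the compounds shown here, the earlier pair spoke only to configuration; this is the first evidence on a substituent, and it shows that this position tolerates the exchange of bromo for cyano, with its triple bond and hydrogen-bond acceptor, without a step beyond the scatter. Nothing on record bears on why the exchange leaves the number within the scatter.

From the compounds shown here alone, it remains open whether an amine, a methoxy group or a carboxylic acid on this carbon would also stay within the scatter of compound 1. Also open, going by these compounds, is whether cyano would behave the same way on the mirror-image configuration of compound 2.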